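A Nitrophenyl Swap on the Amide Nitrogen

The compounds below may be only part of what the source reports. "The series", "measured", "known", "first", "only" and "open" are said of these compounds alone.

For the measured compounds named here, in an ADME assay on MT4 cells (Homo sapiens) for cytotoxicity, read by MTT assay (a lower number here means that less compound is tolerated, a higher number that more compound is tolerated), three compounds have numbers so far. Compound 1 `O=C(CSc1nncnc1-c1cccc2ccccc12)Nc1ccccc1[N+](=O)[O-]` gives 142000 nM and compound 2 `O=C(CSc1nncnc1-c1ccccc1Cl)Nc1ccccc1` gives 127000 nM as the half-maximal cytotoxic concentration. Compound 3 `COC(=O)c1sccc1NC(=O)CSc1nncnc1-c1ccccc1Cl` gives 105000 nM and lies within the scatter of both others, so the three cannot be ranked. Compound 4 `O=C(CSc1nncnc1-c1ccccc1Cl)Nc1ccccc1[N+](=O)[O-]` differs from compound 3 by 2-nitrophenyl in place of 2-(methoxycarbonyl)thiophen-3-yl on an amide-type nitrogen and so has 2-nitrophenyl in place of 2-(methoxycarbonyl)thiophen-3-yl on an amide-type nitrogen. Going by the values given here, the only measured step at this nitrogen is a 1.2-fold lower number from compound 2 to compound 3 (0.08 log units; within the scatter) and it stays within the scatter. Compound 1 also carries 2-nitrophenyl on that nitrogen, though its structure differs from that of compound 4 elsewhere. The value of compound 1, 142000 nM, lies within the scatter of compound 3. What is expected in this assay is therefore no change beyond the scatter, with a 1.1-fold higher number from compound 3 to compound 4 (0.06 log units; within the scatter) as the estimated step. Compound 4 is estimated at 120000 nM with 70000 nM to 200000 nM as the expected range.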

Compound 4, half-maximal cytotoxic concentration: 63000 nM
Beside the measured number, compound 4's estimate is 1.9-fold (0.28 log units) above it; measured number outside the range, below it.
By their numbers in this assay, from the lowest: compounds 4, 3, 2 and 1 (each within the scatter of the next, the first and the last beyond it).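

In this assay, 2-nitrophenyl in place of 2-(methoxycarbonyl)thiophen-3-yl on the amide-type nitrogen gives a 1.7-fold lower number from compound 3 to compound 4 (0.22 log units; within the scatter) and stays inside the usual spread, while nitro in place of hydrogen on an aromatic carbon gives a 2.0-fold lower number from compound 2 to compound 4 (0.30 log units; within the scatter) and also does not leave it. For the compounds shown here, the one step beyond the scatter lies away from this nitrogen: with 2-nitrophenyl held there, 2-chlorophenyl in place of naphthalen-1-yl gives a 2.3-fold lower number from compound 1 to compound 4 (0.35 log units; beyond the scatter), a modest step. No measurement at hand accounts for any of these steps.

On these data alone, whether an amine or a carboxylic acid in place of the nitro would move the number beyond the scatter remains open. So does whether the step from naphthalen-1-yl to 2-chlorophenyl would be the same size with a different group on the nitrogen.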